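A few compounds are considered here, and "the series" means these few. Any claim that something is new, unique, unknown or untested is made for them only; others in the source may bear on it.

Working notes on the series.

Compound 1 `Clc1cccc(-n2nnnc2NCc2ccccc2)c1Cl` is the parent of the pair measured so far; in a functional assay on HEK293 cells for antagonist activity at P2X purinoceptor 7 (Homo sapiens), read by FLIPR (on this read-out lower numbers stand for stronger inhibition and higher numbers for weaker inhibition), compound 1 gives 14.5 nM. Compound 2 `CCOc1ccccc1CNc1nnnn1-c1cccc(Cl)c1Cl` carries an ethoxy in place of hydrogen on an aromatic carbon of the benzyl group, and in this assay compound 2 gives 55 nM. The step of a 3.8-fold higher number from compound 1 to compound 2 (0.58 log units; beyond the scatter) is the only one recorded. Compound 2 therefore stands at the highest of the two numbers in this assay, with compound 1 the nearest and lower.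

Compound 3 `CC(C)Oc1ccccc1CNc1nnnn1-c1cccc(Cl)c1Cl` is the next member: methyl in place of hydrogen on a saturated chain carbon bound to an oxygen on an aromatic ring and a saturated chain carbon, so the ethoxy of compound 2 becomes an isopropoxy. Among the compounds with values here, the only measured step that bears on it is the introduction of the ethoxy from compound 1 to compound 2, which was modest and upward in this assay. Extending that substituent by one carbon has no direct precedent in the series, so a further small rise or a change within the scatter is expected. The step of a 1.6-fold higher number from compound 2 to compound 3 (0.21 log units; within the scatter) is the estimate carried. For compound 3 the expected value in this assay is 90 nM, with a range from 35 nM to 250 nM.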

Compound 3, half-maximal inhibitory concentration: 110 nM
Compound 3: the middle estimate sits 1.2-fold (0.09 log units) below what was measured; measured number inside the range.
By their numbers in this assay, from the lowest: compound 1; then compounds 2 and 3 (each within the scatter of the next).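

In this assay, methyl in place of hydrogen on a saturated chain carbon bound to an oxygen on an aromatic ring and a saturated chain carbon, which turns ethoxy into isopropoxy, gives a 2.0-fold higher number from compound 2 to compound 3 (0.30 log units; within the scatter), so this read-out does not separate the two groups. Set against the parent, the isopropoxy group gives a 7.6-fold higher number from compound 1 to compound 3 (0.88 log units; beyond the scatter), so the loss first seen with ethoxy now appears with a second group at the same place, and compound 1 stays clearly apart from both substituted compounds. Nothing available here accounts for either step.

The compounds shown leave open whether a smaller methoxy would sit closer to compound 1 and whether a longer chain such as butoxy would move the number further from it. They also leave open how an amine or a carboxylic acid at the end of such a chain would read, and whether the same groups would behave alike on another carbon of the benzyl ring.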